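Cytotoxicity of the series: one number, two limits

This account rests on a few compounds, and the source may have more. Where it says the series, first, only, none or still open, it means among the compounds named here.

Measured in an ADME assay on Vero cells (Chlorocebus sabaeus) for cytotoxicity; a lower number here means that less compound is tolerated, a higher number that more compound is tolerated:
- compound 1 `Oc1ccc(-c2nc3c(NC4CCCC4)cccn3c2-c2ccnc(NC3CCCC3)n2)cc1`: > 40000 nM (a limit)
- compound 2 `Cc1ccc(-c2nc3c(NC4CCCC4)cccn3c2-c2ccnc(NC3CCCC3)n2)cc1`: > 40000 nM (a limit)
- compound 3 `Fc1ccc(-c2nc3c(NC4CC4)cccn3c2-c2ccnc(NC3CCCC3)n2)cc1`: 33000 nM

Within the data shown here, compound 3 at 33000 nM holds the only actual number in the set. The other two values stand at the limit of > 40000 nM in this assay, at which 2 of the 3 values shown sit, so neither is a number.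

The unmeasured compound 4 `COCCNc1cccn2c(-c3ccnc(NC4CCCC4)n3)c(-c3ccc(F)cc3)nc12` follows from compound 3 by one change: 2-methoxyethyl in place of cyclopropyl on a nitrogen on an aromatic ring. The three-membered non-aromatic ring leaves with the cyclopropyl, and the 2-methoxyethyl brings no ring.

Among the measured compounds shown here, the single measured step is a step that the two limits leave unreadable from compound 1 to compound 2. It concerns a group on an aromatic carbon, not the substituent on this nitrogen, and it offers no size to carry over. For the measured compounds named here, no measured step therefore bears directly on the change, and no direction can be drawn from the data. Going by the values given here, the only anchor is compound 3 at 33000 nM, so no shift beyond the scatter is expected in this assay.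

The expected step is a 1.1-fold higher number from compound 3 to compound 4 (0.03 log units; within the scatter).

For compound 4 the estimated value is 35000 nM, with an expected range of 17000 nM to 65000 nM.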

Compound 4, half-maximal cytotoxic concentration: > 40000 nM
Compound 4 ended at the assay's limit (the forecaster's own chance of this, stated with the estimate: 50%); middle value at least 1.1-fold (0.05 log units) away from the limit.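

In this assay, among these compounds, the first readable step on this nitrogen comes with cyclopropylamino going to (2-methoxyethyl)amino: an at least 1.2-fold higher number from compound 3 to compound 4 (0.08 log units; that floor lies within the scatter). Compound 4 stands at > 40000 nM, a limit and not a number. The ring on this nitrogen is therefore not needed to keep the number in this assay from falling, as the open 2-methoxyethyl chain gives no lower reading, and compound 3 remains the only compound with an actual number: the limit of > 40000 nM in this assay, at which 3 of the 4 values shown sit.

As far as these compounds go, how far compound 4 lies beyond that limit remains open, so the true size of the step cannot be told. Also open, from the compounds shown here alone, is whether this nitrogen would tolerate a chain ending in an amine or a carboxylic acid as well, or a longer chain, in this assay.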